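Bicyclic arylmethyl side chains in a macrocyclic motilin ligand

This account rests on a few compounds, and the source may have more. Where it says the series, first, only, none or still open, it means among the compounds named here.

The series rests on a shared macrocyclic core in which one side chain is varied. Compound 1 `CCC[C@@H]1NC(=O)[C@@H](C(C)C)NC(=O)[C@@H](c2ccccc2)NCCOc2ccccc2CCCNC1=O` carries a phenyl group on a saturated ring carbon; in an assay on isolated protein for displacement of a labelled ligand from Motilin receptor (Homo sapiens) (on this read-out higher numbers stand for weaker inhibition and lower numbers for stronger inhibition), compound 1 reaches only a limit, > 10000 nM. Compound 2 `CCC[C@@H]1NC(=O)[C@@H](C(C)C)NC(=O)[C@@H](Cc2c[nH]c3ccccc23)NCCOc2ccccc2CCCNC1=O` bears an (1H-indol-3-yl)methyl group instead and in this assay compound 2 gives 255 nM. Compound 3 `CCC[C@@H]1NC(=O)[C@@H](C(C)C)NC(=O)[C@@H](Cc2ccc3ccccc3c2)NCCOc2ccccc2CCCNC1=O` bears a (naphthalen-2-yl)methyl group and in this assay compound 3 gives 79 nM, the lowest number among the two measured values, the nearest being compound 2. The steps of an at least 39-fold lower number from compound 1 to compound 2 (1.59 log units; beyond the scatter) and an at least 120-fold lower number from compound 1 to compound 3 (2.10 log units; beyond the scatter) are stated only as lower bounds because of the limit of > 10000 nM in this assay, at which 1 of the 3 values shown sits. Between the two bicyclic groups the step of a 3.2-fold lower number from compound 2 to compound 3 (0.51 log units; beyond the scatter) is modest.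

Compound 4 `CCC[C@@H]1NC(=O)[C@@H](C(C)C)NC(=O)[C@@H](Cc2csc3ccccc23)NCCOc2ccccc2CCCNC1=O` differs from compound 3 by 1-benzothiophen-3-yl in place of naphthalen-2-yl on a saturated chain carbon bound to a saturated ring carbon. The new group keeps two fused aromatic rings, as in compound 2 and compound 3, but replaces a carbon ring with a sulfur-containing five-membered ring. Both measured bicyclic analogues sit well away from the phenyl compound, so in this assay compound 4 is expected to land between them, with a step of a 1.6-fold higher number from compound 3 to compound 4 (0.22 log units; within the scatter) relative to compound 3. The estimate for compound 4 is 130 nM, with a range from 40 nM to 450 nM.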

Compound 4, inhibition constant: 11 nM
Estimate against measurement, compound 4: 12-fold (1.07 log units) above; measured number below the stated range.
By their numbers in this assay, from the lowest: compound 4; then compound 3; then compound 2. At a limit, above all of these: compound 1.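

Compound 2 and compound 3 showed that both fused bicyclic arylmethyl groups gave measurable values where phenyl did not, but they left the choice among such groups looking modest. In this assay, compound 4 shows that this choice on the saturated chain carbon still carries real weight, with a 7.2-fold lower number from compound 3 to compound 4 (0.86 log units; beyond the scatter) and a 23-fold lower number from compound 2 to compound 4 (1.37 log units; beyond the scatter), and the large second step separates two groups that each fuse a five-membered aromatic ring to a six-membered one, with sulfur in one and nitrogen in the other, so the identity of the hetero atom or of the whole ring system matters here, while a bicyclic group with fewer heavy atoms than naphthalen-2-yl gives the lowest number of the series. The comparison with phenyl, an at least 900-fold lower number from compound 1 to compound 4 (2.95 log units; beyond the scatter), can be read only as a lower bound, since compound 1 stands at a limit: the limit of > 10000 nM in this assay, at which 1 of the 4 values shown sits.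

The compounds shown leave open whether the low number of compound 4 follows the sulfur atom itself, which a 1-benzofuran-3-yl group with oxygen in its place would test. They also leave open how much depends on the point of attachment, which a 1-benzothiophen-2-yl or a naphthalen-1-yl group would address.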